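The source may hold more compounds than are shown below. What is called first, only, known or untested is meant among the compounds shown, and "the series" means these compounds.

Of the compounds shown here, two have so far been measured in a functional assay on UO-31 cells (Homo sapiens) for inhibition, read by sulforhodamine B assay, with a stated time of 48 h; on this read-out higher numbers stand for lower toxicity in this test and lower numbers for higher toxicity in this test. Compound 1 `NS(=O)(=O)c1ccc(Nc2nc(N/N=C/c3ccc(C(F)(F)F)cc3)nc(Nc3ccccc3)n2)cc1` gives 15700 nM. Compound 2 `Cc1nn(-c2ccccc2)cc1/C=N/Nc1nc(Nc2ccccc2)nc(Nc2ccc(S(N)(=O)=O)cc2)n1` gives 7270 nM. Going by the values given here, compound 2 therefore stands at the lower of the two numbers, the only measured step, a 2.2-fold lower number from compound 1 to compound 2 (0.33 log units; beyond the scatter), being modest in size. Compound 3 `NS(=O)(=O)c1ccc(Nc2nc(N/N=C/c3ccccn3)nc(Nc3ccccc3)n2)cc1` has not yet been measured; it differs from compound 2 in one place: pyridin-2-yl in place of 3-methyl-1-phenyl-1H-pyrazol-4-yl on a carbon with a double bond to nitrogen. Among the compounds with values here, no measured step involves pyridin-2-yl at this position. Within the data shown here, the single step in hand, a 2.2-fold lower number from compound 1 to compound 2 (0.33 log units; beyond the scatter), concerns an exchange of one ring group for another on the same carbon with a double bond to nitrogen, and it was modest; a further exchange of ring group at this carbon is therefore expected to shift the number only modestly, with no firm direction. For compound 3 the number in this assay is estimated at 10000 nM, within 3500 nM to 30000 nM, which amounts to an expected step of a 1.4-fold higher number from compound 2 to compound 3 (0.14 log units; within the scatter).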

Compound 3, concentration lethal to 50% of the cells: 89500 nM
Estimate against measurement, compound 3: 9.0-fold (0.95 log units) below; measured number above the stated range.
By their numbers in this assay, from the lowest: compound 2; then compound 1; then compound 3.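

In this assay, the ring group on the carbon with a double bond to nitrogen can move the number by much more than the first pair suggested: pyridin-2-yl in place of 3-methyl-1-phenyl-1H-pyrazol-4-yl gives a 12-fold higher number from compound 2 to compound 3 (1.09 log units; beyond the scatter), and pyridin-2-yl in place of 4-(trifluoromethyl)phenyl gives a 5.7-fold higher number from compound 1 to compound 3 (0.76 log units; beyond the scatter). Both steps point the same way, so among these three groups pyridin-2-yl carries the highest number, meaning the lowest toxicity in this test. No measurement on hand accounts for this difference.

Pyridin-2-yl differs from 4-(trifluoromethyl)phenyl both in its ring nitrogen and in lacking the trifluoromethyl group, so the shown compounds do not separate these two changes. Unsubstituted phenyl or pyridin-4-yl at this carbon would bear on that question, and the effect of an amine or carboxylic acid there remains open.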